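3-Chlorophenyl gives way to 4-hydroxyphenyl

This account rests on a few compounds, and the source may have more. Where it says the series, first, only, none or still open, it means among the compounds named here.

- compound 1 `O=C1OC[C@H](Cc2ccccc2)[C@H]1Cc1ccccc1O`: 83000 nM
- compound 2 `O=C1OC[C@H](Cc2ccccc2)[C@H]1Cc1cccc(Cl)c1`: 36000 nM

Within the data shown here, in a functional assay on HL-60 cells (Homo sapiens) for cytotoxicity, read by WST assay, with a stated time of 48 h (on this read-out higher numbers stand for an effect only at larger amounts of compound and lower numbers for an effect already at smaller amounts), compound 2 holds the lower of the two numbers, and compound 1 is its only neighbour. Compound 3 `O=C1OC[C@H](Cc2ccccc2)[C@H]1Cc1ccc(O)cc1` is still unmeasured and carries 4-hydroxyphenyl in place of 3-chlorophenyl on the same saturated chain carbon: 4-hydroxyphenyl in place of 3-chlorophenyl on a saturated chain carbon bound to a saturated ring carbon. Among the measured compounds shown here, one measured step bears on this change, namely a 2.3-fold lower number from compound 1 to compound 2 (0.36 log units; beyond the scatter), which was modest and introduced 3-chlorophenyl in place of 2-hydroxyphenyl. For the measured compounds named here, the present change runs the opposite way, from chlorophenyl back to a hydroxyphenyl, although no measured compound carries 4-hydroxyphenyl. A similarly modest rise in the number is therefore expected in this assay, and the estimated step is a 2.1-fold higher number from compound 2 to compound 3 (0.32 log units; beyond the scatter) overall. For compound 3 the estimate is 75000 nM with an expected range from 30000 nM to 170000 nM in this assay.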

Compound 3, half-maximal effective concentration: 88000 nM
Beside the measured number, compound 3's estimate is 1.2-fold (0.07 log units) below it; low and high end bracket the measured number.
By their numbers in this assay, from the lowest: compound 2; then compounds 1 and 3 (each within the scatter of the next).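

In this assay, 4-hydroxyphenyl does not keep the lower number that 3-chlorophenyl holds at this saturated chain carbon: the result is a 2.4-fold higher number from compound 2 to compound 3 (0.39 log units; beyond the scatter) and the step is modest. The two hydroxyphenyl groups cannot be told apart here, with a 1.1-fold higher number from compound 1 to compound 3 (0.03 log units; within the scatter) for the exchange of 2-hydroxyphenyl for 4-hydroxyphenyl. Of the three groups, only 3-chlorophenyl in compound 2 stands apart, and the hydroxyl's change of place on the phenyl ring shifts nothing beyond the scatter.

The compounds shown leave open whether the lower number of compound 2 goes with the chlorine itself or with where it sits, as no chlorophenyl and hydroxyphenyl here share a position. As far as these compounds go, how an amine or a carboxylic acid on that phenyl ring, or a longer chain at this carbon, would read also stays open. No measurement at hand gives a reason for these steps.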